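From 3-hydroxyphenyl to 3-bromo-4-hydroxyphenyl at the assay limit

A few compounds are considered here, and "the series" means these few. Any claim that something is new, unique, unknown or untested is made for them only; others in the source may bear on it.

In a functional assay on HepG2 cells (Homo sapiens) for antiproliferative activity, read by MTT assay, with a stated time of 24 h (on this read-out higher numbers stand for weaker inhibition and lower numbers for stronger inhibition), compound 1 (`COc1ccc(C(=O)/C=C/c2cccc([N+](=O)[O-])c2)c2c1C=CC(C)(C)O2`) gives 2830 nM. Compound 2 (`COc1ccc(C(=O)/C=C/c2ccc(O)cc2)c2c1C=CC(C)(C)O2`) gives only a limit, > 10000 nM. Compound 3 (`COc1ccc(C(=O)/C=C/c2cccc(O)c2)c2c1C=CC(C)(C)O2`) likewise gives only a limit, > 10000 nM, and so has no number of its own. It stands at the limit of > 10000 nM in this assay, at which 2 of the 3 values shown sit.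

Compound 4 (`COc1ccc(C(=O)/C=C/c2ccc(O)c(Br)c2)c2c1C=CC(C)(C)O2`) has not yet been measured. Its difference is 3-bromo-4-hydroxyphenyl in place of 3-hydroxyphenyl on a double-bonded chain carbon bound to a double-bonded chain carbon, with 3-bromo-4-hydroxyphenyl in place of 3-hydroxyphenyl. The closest evidence is an at least 3.5-fold higher number from compound 1 to compound 2 (0.54 log units; beyond the scatter) and an at least 3.5-fold higher number from compound 1 to compound 3 (0.54 log units; beyond the scatter), both beyond the scatter, whereas a step that the two limits leave unreadable from compound 2 to compound 3 cannot be read. Within the data shown here, neither hydroxyphenyl compound yields a number, and no measured compound carries bromo. Given an at least 3.5-fold higher number from compound 1 to compound 3 (0.54 log units; beyond the scatter), only a modest step toward lower numbers in this assay is expected, and a result that stays at the limit would be no surprise. The estimated step is an at least 1.2-fold lower number from compound 3 to compound 4 (0.09 log units; that floor lies within the scatter). For compound 4, the estimated value is 8000 nM, within an expected range of 2500 nM to 20000 nM.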

Compound 4, half-maximal inhibitory concentration: > 10000 nM
Compound 4: a limit, no number; the forecaster's own chance of this, stated with the estimate: 55%; at least 1.2-fold (0.09 log units) between middle value and limit.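

In this assay compound 4 gives > 10000 nM, which is a limit of the assay and not a number. Bromo in place of hydrogen on an aromatic carbon thus brings no number into the hydroxyphenyl compounds, and the steps among compound 2, compound 3 and compound 4 cannot be read, as all three stand at limits. Among these compounds, the one readable comparison is an at least 3.5-fold higher number from compound 1 to compound 4 (0.54 log units; beyond the scatter), so 3-bromo-4-hydroxyphenyl joins the two hydroxyphenyl groups on the side of higher numbers relative to 3-nitrophenyl at this place.

As far as these compounds go, how far compound 2, compound 3 and compound 4 lie past the limit remains unknown, so any effect of bromo on them stays hidden. Also open, from the compounds shown here alone, is whether an amine or a carboxylic acid on this phenyl ring would give a number in this assay.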